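Nitro for butyl on the sulfonamide aryl ring

The compounds below may be only part of what the source reports. "The series", "measured", "known", "first", "only" and "open" are said of these compounds alone.

Compound 1, `CCCCc1ccc(S(=O)(=O)NCCCCCCNCc2ccc(Br)cc2)cc1`: 5700 nM
Compound 2, `O=S(=O)(NCCCNCc1ccc(Cl)cc1)c1cc(C(F)(F)F)cc(C(F)(F)F)c1`: 2800 nM

The two measured compounds were tested in a functional assay on MIA PaCa-2 cells (Homo sapiens) for inhibition, read by MTT assay, with a stated time of 72 h; a lower number here means a stronger inhibitor of growth, a higher number a weaker inhibitor of growth. Compound 1 gives 5700 nM, the higher of the two numbers; compound 2 gives 2800 nM, a lower number by a step beyond the scatter, so compound 1 is the weaker inhibitor of growth of the pair.

Compound 3, `O=[N+]([O-])c1ccc(S(=O)(=O)NCCCCCCNCc2ccc(Br)cc2)cc1`, has not yet been measured. It differs from compound 1 in one place: nitro in place of butyl on an aromatic carbon, on an aromatic carbon of a six-membered aromatic ring of carbon only, para to a large group. Within the data shown here, no measured pair shows what such a change does here, so the expectation rests on compound 1 alone. The step from compound 1 to compound 3 is expected to be small, a 1.1-fold higher number from compound 1 to compound 3 (0.06 log units; within the scatter), with no confident direction beyond the scatter. Compound 3 is therefore estimated at 6500 nM, in a range from 2200 nM to 19000 nM.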

Compound 3, concentration for 50% growth inhibition: 9800 nM
For compound 3 the middle estimate is 1.5-fold (0.18 log units) below the measured one; measured number inside the range.
By their numbers in this assay, from the lowest: compound 2; then compounds 1 and 3 (each within the scatter of the next).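

Among these compounds, putting nitro in place of butyl on an aromatic carbon gives a 1.7-fold higher number from compound 1 to compound 3 (0.24 log units; within the scatter) in this assay, the first step in this set that changes only one place. At this position, para to a large group, a group of carbon only and a group of nitrogen and oxygen carrying hydrogen-bond acceptors therefore give numbers that stay within the scatter of each other, so this one change does not separate compound 1 from compound 3. Nothing measured here bears on why the step came out this way.

The compounds shown leave open whether an amine, a carboxylic acid or a longer alkyl chain on this aromatic carbon would give a step beyond the scatter. Going by these compounds, compound 2 differs from both compound 1 and compound 3 in more than one place, so the effect of the chain linking the sulfonamide to the amine also stays open.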